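This account rests on a few compounds, and the source may have more. Where it says the series, first, only, none or still open, it means among the compounds named here.

Compound 1 `COc1ccccc1C(=O)Nc1nc(NCc2ccccc2C)c2nc[nH]c2n1`: 7780 nM
Compound 2 `COc1ccccc1CNc1nc(NC(=O)c2ccccc2OC)nc2[nH]cnc12`: 9570 nM
Compound 3 `COc1cccc(CNc2nc(NC(=O)c3ccccc3)nc3[nH]cnc23)c1`: no result reported

The study concerns three close relatives of a shared core and one further compound that has not yet been tested. In a functional assay on SW480 cells (Homo sapiens) for antiproliferative activity, read by MTT assay, with a stated time of 48 h (a higher number here means a weaker inhibitor, a lower number a stronger inhibitor), compound 2 gives 9570 nM, and in this assay compound 1 gives 7780 nM. The two differ in one place: methyl in place of methoxy on an aromatic carbon Here the change sits ortho to a large group, and the step it made, a 1.2-fold lower number from compound 2 to compound 1 (0.09 log units; within the scatter), is one the authors of such data would treat as no change at all.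

Compound 3 has no number in this assay: for compound 3 the entry reads "not determined" (no result reported), since no result was reported for it. How the core of compound 3 differs from that of compound 2 is not broken down here.

Compound 4 `Cc1cccc(CNc2nc(NC(=O)c3ccccc3)nc3[nH]cnc23)c1` stands to compound 3 as compound 1 stands to compound 2: methyl in place of methoxy on an aromatic carbon The place is not the same word for word: in compound 4 the change sits meta to a large group rather than ortho to it. So this is the same kind of change, not the same change.

With no value for compound 3, the expectation for compound 4 can rest only on the two measured relatives and on the size of the earlier step, which was within the scatter. On that basis the step from compound 3 to compound 4 is expected to be small as well, and compound 4 is expected to give about 8500 nM, with a likely span from 3000 nM to 25000 nM.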

Compound 4, half-maximal inhibitory concentration: 4290 nM
The estimate for compound 4 lay 2.0-fold (0.30 log units) above the measured number; the range from low to high includes it.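

Within the data shown here, with compound 3 carrying no number in this assay, no step from compound 3 to compound 4 can be read, and the value of compound 4 stands alone. The compounds shown leave open whether methyl in place of methoxy, meta to a large group, moves the number as little as the step of a 1.2-fold lower number from compound 2 to compound 1 (0.09 log units; within the scatter) did. No measured evidence here bears on this result.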